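Adding a third methoxy group to compound 2

A few compounds are considered here, and "the series" means these few. Any claim that something is new, unique, unknown or untested is made for them only; others in the source may bear on it.

Compound 1 `Cc1cc(O)c(C2=NN(c3ccc(S(N)(=O)=O)cc3)C(/C=C/c3ccccc3)C2)cc1Cl` gives 12500 nM in a functional assay on 786-0 cells (Homo sapiens) for antiproliferative activity, with a stated time of 48 h; on this read-out lower numbers stand for stronger inhibition of growth and higher numbers for weaker inhibition of growth. Going by the values given here, compound 2 `COc1ccc(C2CC(c3cc(Cl)c(C)cc3O)=NN2c2ccc(S(N)(=O)=O)cc2)cc1OC` gives 5040 nM in this assay, the lowest of the two numbers so far, separated from compound 1 by the single measured step, a 2.5-fold lower number from compound 1 to compound 2 (0.39 log units; beyond the scatter). Compound 3 `COc1ccc(C2CC(c3cc(Cl)c(C)cc3O)=NN2c2ccc(S(N)(=O)=O)cc2)c(OC)c1OC` carries methoxy in place of hydrogen on an aromatic carbon, turning 3,4-dimethoxyphenyl into 2,3,4-trimethoxyphenyl. Among the compounds with values here, no measured step covers a change of this kind: the only step known exchanges a whole substituent on the saturated ring carbon, 2-phenylethenyl for 3,4-dimethoxyphenyl, and says nothing about a further methoxy group on that phenyl. Within the data shown here, with no precedent, the working expectation for compound 3 is no step beyond the scatter, a 1.0-fold lower number from compound 2 to compound 3 (0.00 log units; within the scatter). Compound 3 is therefore estimated at 5000 nM, with a range from 2000 nM to 12500 nM.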

Compound 3, concentration for total growth inhibition: 4290 nM
Compound 3: the middle estimate sits 1.2-fold (0.07 log units) above what was measured; low and high end bracket the measured number.
By their numbers in this assay, from the lowest: compounds 3 and 2 (each within the scatter of the next); then compound 1.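

In this assay methoxy in place of hydrogen on an aromatic carbon, ortho to a large group and ortho to a methoxy group, gives a step within the scatter (a 1.2-fold lower number from compound 2 to compound 3 (0.07 log units; within the scatter)), so this position of the 3,4-dimethoxyphenyl accepts a further methoxy group with no readable change in the number. Against 2-phenylethenyl on the saturated ring carbon, 2,3,4-trimethoxyphenyl gives a modest step beyond the scatter (a 2.9-fold lower number from compound 1 to compound 3 (0.46 log units; beyond the scatter)), so the gain seen with 3,4-dimethoxyphenyl is kept with the added methoxy group. Nothing in hand explains why the added methoxy group leaves the number within the scatter.

On these data alone, whether this position responds to a different group, such as a hydroxyl, an amine or a carboxylic acid, stays open. As far as these compounds go, the effect of any change to the chlorine, methyl or hydroxyl groups on the other phenyl ring also stays open, since all three compounds share them.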